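The source may hold more compounds than are shown below. What is called first, only, known or untested is meant among the compounds shown, and "the series" means these compounds.

Measured compounds in a functional assay on MGC-803 cells (Homo sapiens) for inhibition, read by MTT assay, with a stated time of 72 h; on this read-out lower numbers stand for stronger inhibition and higher numbers for weaker inhibition:
compound 1 `COc1ccc(Nc2nc(SCc3cn(Cc4ccccc4Cl)nn3)nc(-c3ccccc3)c2C#N)cc1` gives 7560 nM
compound 2 `N#Cc1c(Nc2ccccc2Cl)nc(SCc2cn(Cc3ccccc3Cl)nn2)nc1-c1ccccc1` gives 4640 nM
compound 3 `N#Cc1c(Nc2ccc(Cl)cc2)nc(SCc2cn(Cc3ccccc3Cl)nn2)nc1-c1ccccc1` gives 5850 nM

Compound 3 sits among the three numbers with both neighbours close: a 1.3-fold lower number from compound 1 to compound 3 (0.11 log units; within the scatter) and a 1.3-fold higher number from compound 2 to compound 3 (0.10 log units; within the scatter) are each within the scatter, as is a 1.6-fold lower number from compound 1 to compound 2 (0.21 log units; within the scatter).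

Compound 4 `COc1ccccc1Nc1nc(SCc2cn(Cc3ccccc3Cl)nn2)nc(-c2ccccc2)c1C#N` is not yet measured. Its change from compound 3 is 2-methoxyphenyl in place of 4-chlorophenyl on a nitrogen on an aromatic ring. Two of the measured steps bear on it: the exchange of chloro for methoxy at the same place on the aryl group, seen in a 1.3-fold lower number from compound 1 to compound 3 (0.11 log units; within the scatter), and the move of a substituent on that aryl group, seen in a 1.3-fold higher number from compound 2 to compound 3 (0.10 log units; within the scatter). For the measured compounds named here, both were within the scatter, and no step in this set exceeds it.

For compound 4 in this assay no step beyond the scatter is expected; the estimated value is 5500 nM, range 2500 nM to 12000 nM, which means an expected 1.1-fold lower number from compound 3 to compound 4 (0.03 log units; within the scatter).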

Compound 4, half-maximal inhibitory concentration: 5800 nM
The estimate for compound 4 lay 1.1-fold (0.02 log units) below the measured number, within the range that was stated.
By their numbers in this assay, from the lowest: compounds 2, 4, 3 and 1 (each within the scatter of the next).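

With 2-methoxyphenyl on the nitrogen, all four aryl groups in this assay stay within the scatter of one another: a 1.0-fold lower number from compound 3 to compound 4 (0.00 log units; within the scatter), a 1.3-fold higher number from compound 2 to compound 4 (0.10 log units; within the scatter) and a 1.3-fold lower number from compound 1 to compound 4 (0.12 log units; within the scatter). Chloro and methoxy can now be compared at the same place on two cores, and the two steps agree within the scatter: the same change on two cores in this assay, a 1.3-fold lower number (0.11 log units; within the scatter) from compound 1 to compound 3 and a 1.3-fold lower number (0.10 log units; within the scatter) from compound 4 to compound 2, 1.0-fold (0.01 log units) apart, within the scatter of two such steps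

As far as these compounds go, whether any group on this nitrogen gives a step beyond the scatter remains open. An aryl group carrying an amine or a carboxylic acid, or a longer chain in place of the aryl group, would test this.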